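Turning Compound 1 Into Its Mirror Image

The compounds below may be only part of what the source reports. "The series", "measured", "known", "first", "only" and "open" are said of these compounds alone.

In a functional assay on RAW264.7 cells (Mus musculus) for inhibition, read by Griess assay, with stated times of 1 h and 20 h (on this read-out higher numbers stand for weaker inhibition and lower numbers for stronger inhibition), compound 1 `C[C@@H]1C[C@@H]2CCCN2[C@H](CC(=O)C[C@H]2N3CCC[C@H]3C[C@@H](C)[C@]2(O)c2ccccc2)[C@@]1(O)c1ccccc1` gives 22800 nM and compound 2 `CC(=O)CCCC[C@H]1C[C@@H](C)[C@@](O)(c2ccccc2)CN1` gives 27600 nM, two numbers within the scatter of each other. Compound 3 `C[C@H]1C[C@H]2CCCN2[C@@H](CC(=O)C[C@@H]2N3CCC[C@@H]3C[C@H](C)[C@@]2(O)c2ccccc2)[C@]1(O)c1ccccc1` has the same atoms and bonds as compound 1, and all stereocentres are inverted, which makes them mirror images: the two compounds have the same atoms and bonds and differ only in configuration as drawn: 8 of 8 stereo elements differ (all stereocentres are inverted: mirror images); a stereocentre at a saturated ring carbon is drawn R in compound 1 and S in compound 3; a stereocentre at a saturated ring carbon is drawn S in compound 1 and R in compound 3; a stereocentre at a saturated ring carbon is drawn R in compound 1 and S in compound 3; a stereocentre at a saturated ring carbon is drawn R in compound 1 and S in compound 3. Among the compounds with values here, no measured pair here shows what such an inversion does, so the expectation rests on compound 1 at 22800 nM. No change beyond the scatter is expected in this assay, with an estimated 1.0-fold higher number from compound 1 to compound 3 (0.00 log units; within the scatter) as the step. For compound 3 the expected value is 23000 nM, within an estimated range of 10000 nM to 50000 nM.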

Compound 3, half-maximal inhibitory concentration: 3600 nM
Estimate against measurement, compound 3: 6.4-fold (0.81 log units) above; the whole stated range lies above it.
By their numbers in this assay, from the lowest: compound 3; then compounds 1 and 2 (each within the scatter of the next).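

In this assay, inverting every stereocentre gives a 6.3-fold lower number from compound 1 to compound 3 (0.80 log units; beyond the scatter), so stronger inhibition here can be reached without adding or removing a single atom. Compounds 1 and 2 could not show this, since they differ in more than configuration and their values sit within the scatter of each other. The step can be traced to three-dimensional arrangement alone: the fact that compounds 1 and 3 differ only in the configuration as drawn

All the centres change together. The step does not reveal which of them matter. As far as these compounds go, whether the stronger inhibition of compound 3 would survive adding a carboxylic acid also remains open.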